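The source may report more compounds than this note shows. Statements on the series, on what has been measured and on what is new or still open speak of the compounds shown alone.

For the measured compounds named here, in a functional assay on HeLa cells (Homo sapiens) for inhibition, read by MTT assay, with a stated time of 48 h (a higher number here means a weaker inhibitor, a lower number a stronger inhibitor), compound 1 `OC[C@H]1O[C@@H](n2cc(C(c3ccc(Cl)cc3)c3cn([C@@H]4O[C@H](CO)[C@@H](O)[C@H](O)[C@H]4O)c4ccc(Br)cc34)c3cc(Br)ccc32)[C@H](O)[C@@H](O)[C@@H]1O` gives 32000 nM and compound 2 `OC[C@H]1O[C@@H](n2cc(C(c3ccc(Br)cc3)c3cn([C@@H]4O[C@H](CO)[C@@H](O)[C@H](O)[C@H]4O)c4ccc(Br)cc34)c3cc(Br)ccc32)[C@H](O)[C@@H](O)[C@@H]1O` gives 27000 nM, so compound 2 stands level with the only other measured compound. Compound 3 `O=[N+]([O-])c1ccc(C(c2cn([C@@H]3O[C@H](CO)[C@@H](O)[C@H](O)[C@H]3O)c3ccc(Br)cc23)c2cn([C@@H]3O[C@H](CO)[C@@H](O)[C@H](O)[C@H]3O)c3ccc(Br)cc23)cc1` differs from compound 2 by nitro in place of bromo on an aromatic carbon, with nitro in place of bromo on an aromatic carbon, para to a large group. Going by the values given here, the one measured step at this place is a 1.2-fold lower number from compound 1 to compound 2 (0.07 log units; within the scatter), a swap of bromo for chloro. Among the compounds with values here, no measured step covers nitro, so only a weak guide exists, and no shift beyond the scatter is expected in this assay, in either direction. The expected step is a 1.1-fold lower number from compound 2 to compound 3 (0.03 log units; within the scatter). For compound 3 the estimated value is 25000 nM, with an expected range of 10000 nM to 60000 nM.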

Compound 3, half-maximal inhibitory concentration: 30000 nM
Compound 3: middle estimate off by 1.2-fold (0.08 log units), on the low side; the range from low to high includes it.
By their numbers in this assay, from the lowest: compounds 2, 3 and 1 (each within the scatter of the next).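

In this assay, the change from 4-bromophenyl to 4-nitrophenyl gives a 1.1-fold higher number from compound 2 to compound 3 (0.05 log units; within the scatter), and nitro in place of chloro gives a 1.1-fold lower number from compound 1 to compound 3 (0.03 log units; within the scatter). On this aromatic carbon, para to a large group, the series now tolerates more than a swap of one halogen for another: a nitro group with hydrogen-bond acceptors replaces a single halogen atom, and the numbers stay within the scatter. Nothing available bears on why the numbers stay level. On these data alone, whether an amine or a carboxylic acid at this position would move the number beyond the scatter remains open. Also open, as far as these compounds go, is whether changes elsewhere on the shared core would do so.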